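The source may report more compounds than this note shows. Statements on the series, on what has been measured and on what is new or still open speak of the compounds shown alone.

In a functional assay on HEK293 cells for agonist activity at G-protein coupled receptor 39 (Homo sapiens), read by scintillation proximity assay and inositol phosphate accumulation, with a stated time of 75 min (on this read-out lower numbers stand for an effect already at smaller amounts and higher numbers for an effect only at larger amounts of compound), three compounds have been measured:
compound 1 `Cc1nn(-c2ncnc3nc[nH]c23)c2c1C(OCC(=O)c1ccc(F)cc1)CC(=O)N2`: 973 nM
compound 2 `Cc1nn(-c2ncnc3nc[nH]c23)c2c1C(C(=O)N(C)c1nccs1)CC(=O)N2`: 3300 nM
compound 3 `Cc1nn(-c2ncnc3nc[nH]c23)c2c1C(C(=O)NCc1ccccc1)CC(=O)N2`: 2930 nM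

Compound 3 stands second highest of the three; the step of a 1.1-fold lower number from compound 2 to compound 3 (0.05 log units; within the scatter) is within the scatter, while compound 1 sits a clear way below it. Compound 4 `CCCCCCCCOC1CC(=O)Nc2c1c(C)nn2-c1ncnc2nc[nH]c12` differs from compound 3 by octyloxy in place of benzylcarbamoyl on a saturated ring carbon. Among the compounds with values here, no measured step covers this change: the only step recorded, from compound 2 to compound 3, swaps one amide substituent for another and says nothing about an ether in place of the whole carbamoyl group. Compound 1, the one ether among the three, shows the lowest number, but it differs from compound 3 in more than one place. Compound 4 is therefore expected near the measured spread, a 2.0-fold lower number from compound 3 to compound 4 (0.29 log units; within the scatter), with an estimate of 1500 nM and a range from 400 nM to 6000 nM.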

Compound 4, half-maximal effective concentration: 388 nM
Compound 4: the middle estimate sits 3.9-fold (0.59 log units) above what was measured; measured number outside the range, below it.
By their numbers in this assay, from the lowest: compound 4; then compound 1; then compounds 3 and 2 (each within the scatter of the next).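

In this assay octyloxy on the saturated ring carbon gives lower numbers than both carbamoyl groups, with a 7.6-fold lower number from compound 3 to compound 4 (0.88 log units; beyond the scatter) and an 8.5-fold lower number from compound 2 to compound 4 (0.93 log units; beyond the scatter) as the two steps. Among the ethers, heptyl in place of (4-fluorophenyl)carbonyl gives a 2.5-fold lower number from compound 1 to compound 4 (0.40 log units; beyond the scatter) and shows that this position needs neither that carbonyl nor an aromatic ring to reach the lowest number so far. Nothing measured here explains these steps.

As far as these compounds go, whether the ether oxygen matters stays open, since nonyl at this carbon would be needed to test it. From the compounds shown here alone, how butyloxy, dodecyloxy or an octyloxy chain ending in a carboxylic acid or an amine would compare also remains unknown.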